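Methyl for methoxy on the benzamide of compound 2

This account rests on a few compounds, and the source may have more. Where it says the series, first, only, none or still open, it means among the compounds named here.

Compound 1 `COc1cc2ncnc(NNC(=S)NC(=O)c3ccccc3C)c2cc1OC` gives 11400 nM in a functional assay on KB cells (Homo sapiens) for cytotoxicity, read by MTT assay, with a stated time of 72 h; a higher number here means a weaker inhibitor, a lower number a stronger inhibitor. Compound 3 `COc1cc2ncnc(NNC(=S)NC(=O)c3ccccc3OC)c2cc1OC` gives 3850 nM in this assay. Among the compounds with values here, the only measured step that bears on the change below is a 3.0-fold lower number from compound 1 to compound 3 (0.47 log units; beyond the scatter). Compound 2 `COc1ccccc1C(=O)NC(=S)NNc1ncnc2ccccc12` carries the same benzamide as compound 3 but lacks the methoxy groups on the shared core. In this assay compound 2 gives only a limit, > 50000 nM, and not a number, (the limit of > 50000 nM in this assay, at which 1 of the 3 values shown sits). Compound 4 `Cc1ccccc1C(=O)NC(=S)NNc1ncnc2ccccc12` differs from compound 2 in one place: methyl in place of methoxy on an aromatic carbon. This is the reverse of the change from compound 1 to compound 3, so on that step a modestly higher number, weaker inhibition, is expected rather than a lower one. Compound 2 already stands at the limit > 50000 nM. Compound 4 is therefore expected to stand at the limit as well, the expected step being a step that the limit leaves unreadable from compound 2 to compound 4. For compound 4 the estimate is 150000 nM, with a range from 40000 nM to 500000 nM.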

Compound 4, half-maximal inhibitory concentration: 2770 nM
Beside the measured number, compound 4's estimate is 54-fold (1.73 log units) above it; the measured number lies below the stated range.
By their numbers in this assay, from the lowest: compounds 4 and 3 (each within the scatter of the next); then compound 1. At a limit, above all of these: compound 2.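

On the core without the two methoxy groups, going from 2-methoxyphenyl to 2-methylphenyl gives in this assay an at least 18-fold lower number from compound 2 to compound 4 (1.25 log units; beyond the scatter). Compound 2 is held at a limit, > 50000 nM, and not at a number, so this step has no exact size. Even so, the two pairs show that the change does not read the same way on both cores, and that the step on one core does not predict the step on the other: the same change on two cores in this assay, a 3.0-fold lower number (0.47 log units; beyond the scatter) from compound 1 to compound 3 and an at least 18-fold higher number (1.25 log units; beyond the scatter) from compound 4 to compound 2, at least 53-fold (1.72 log units) apart, beyond the scatter of two such steps

Going by these compounds, how a chloro or an ethoxy group at this place on the benzamide would read on either core remains open. Also open, on these data alone, is whether one of the two core methoxy groups alone, or only both together, accounts for the difference between the two pairs.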